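The source may hold more compounds than are shown below. What is called first, only, known or untested is meant among the compounds shown, and "the series" means these compounds.

Working notes on the series. Going by the values given here, in a functional assay on MCF7 cells (Homo sapiens) for antiproliferative activity, read by sulforhodamine B assay, with a stated time of 72 h (on this read-out higher numbers stand for weaker inhibition and lower numbers for stronger inhibition), two compounds carry numbers so far. Compound 2 `N#Cc1ccc(COc2ccc(-c3cc(CN4CCN(Cc5ccc(C(F)(F)F)cc5)CC4)no3)cc2)cc1` gives 100 nM and stands lowest of the two; compound 1 `FC(F)(F)c1ccc(CN2CCN(Cc3cc(-c4ccc(OCc5ccccc5Cl)cc4)on3)CC2)cc1` gives 2800 nM. Among the compounds with values here, the one step between them, a 28-fold lower number from compound 1 to compound 2 (1.45 log units; beyond the scatter), shows that the group on the benzyloxy aromatic ring at the far end of the shared core moves this assay strongly.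

Compound 3 `Fc1ccc(COc2ccc(-c3cc(CN4CCN(Cc5ccc(C(F)(F)F)cc5)CC4)no3)cc2)cc1` differs from compound 2 by fluoro in place of cyano on an aromatic carbon. Within the data shown here, the only step that bears on this position is a 28-fold lower number from compound 1 to compound 2 (1.45 log units; beyond the scatter); it was large, but it exchanged 2-chlorophenyl for 4-cyanophenyl, and no measured pair exchanges cyano for fluoro. The direction is therefore open; the size of that step suggests a change beyond the scatter is possible, and a move back toward the number of compound 1 is taken as the more likely outcome. Compound 3 is expected to give 400 nM, within 120 nM to 1500 nM, which would be the estimated step of a 4.0-fold higher number from compound 2 to compound 3 (0.60 log units; beyond the scatter).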

Compound 3, half-maximal inhibitory concentration: 7900 nM
Estimate against measurement, compound 3: 20-fold (1.30 log units) below; the measured number lies above the stated range.
By their numbers in this assay, from the lowest: compound 2; then compound 1; then compound 3.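

In this assay, fluoro in place of cyano, on an aromatic carbon para to a large group, gives a 79-fold higher number from compound 2 to compound 3 (1.90 log units; beyond the scatter) and so loses the whole of the low number of compound 2. The comparison with the 2-chlorophenyl compound gives a 2.8-fold higher number from compound 1 to compound 3 (0.45 log units; beyond the scatter) and shows that a 4-substituted benzyl group alone does not bring the low number, since 4-fluorobenzyl stands highest of the three. Of these compounds, only the one carrying the nitrile reaches the low number, and nothing given here accounts for the size of the cyano-to-fluoro step.

On these data alone, it remains open whether the nitrile itself is needed or whether a carboxylic acid, a primary amide or a methoxy group at the same place would also give a low number. How far an unsubstituted benzyl group falls within this range is equally unsettled.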